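A few compounds are considered here, and "the series" means these few. Any claim that something is new, unique, unknown or untested is made for them only; others in the source may bear on it.

In an ADME assay on HEK293 cells (Homo sapiens) for antiproliferative activity, read by MTT assay, with a stated time of 24 h (on this read-out lower numbers stand for stronger inhibition and higher numbers for weaker inhibition), compound 2 (`COc1ccc(-c2cc(/C=C/C(=O)c3cc(OC)c(OC)c(OC)c3)nc3cc(-c4ccccc4)nn23)cc1OC`) gives 35000 nM. Compound 3 (`COc1cc(-c2cc(C(=O)/C=C/c3ccc(Cl)cc3)nc3cc(-c4ccccc4)nn23)cc(OC)c1OC`), which differs from it in several places, gives 53900 nM, and these two numbers lie within the scatter of each other. Compound 1 (`COc1cc(C(=O)/C=C/c2cc(-c3cc(OC)c(OC)c(OC)c3)n3nc(-c4ccccc4)cc3n2)cc(OC)c1OC`) reads >= 100000 nM, which is a limit of the assay and not a number. The account now turns to compound 4 (`COc1ccc(-c2cc(/C=C/C(=O)c3ccc(C)cc3)nc3cc(-c4ccccc4)nn23)cc1OC`), which carries 4-methylphenyl in place of 3,4,5-trimethoxyphenyl on a carbonyl carbon. Among the measured compounds shown here, only one measured step bears on this change, and only loosely: an at least 2.8-fold lower number from compound 1 to compound 2 (0.45 log units; beyond the scatter), with hydrogen in place of methoxy on an aromatic carbon. For the measured compounds named here, that step shows that removing a single methoxy can move the number in this assay, but no measured step replaces the whole group on the carbonyl carbon, and so the direction here remains open. No shift beyond the scatter is therefore expected in this assay, although a modest one either way would not surprise. The expected change is a 1.1-fold higher number from compound 2 to compound 4 (0.06 log units; within the scatter). For compound 4 the estimate is 40000 nM, with an expected range from 15000 nM to 100000 nM.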

Compound 4, half-maximal inhibitory concentration: 62600 nM
The estimate for compound 4 lay 1.6-fold (0.19 log units) below the measured number, and the stated range covers the measured number.
By their numbers in this assay, from the lowest: compounds 2, 3 and 4 (each within the scatter of the next). At a limit, above all of these: compound 1.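

In this assay, among the compounds shown here, the group on the carbonyl carbon is now changed directly for the first time: 4-methylphenyl in place of 3,4,5-trimethoxyphenyl gives a 1.8-fold higher number from compound 2 to compound 4 (0.25 log units; within the scatter), and this step lies within the scatter. The group that leaves has 3 hydrogen-bond acceptors and 12 heavy atoms, the group that enters has 0 hydrogen-bond acceptors and 7 heavy atoms, and this exchange produces no shift beyond the scatter. Compound 2 and compound 4 both give numbers, so this step can be read, whereas one value shown stands at a limit and not at a number: the limit of >= 100000 nM in this assay, at which 1 of the 4 values shown sits.

The compounds shown leave open how this position responds to a group of another kind on the carbonyl carbon, such as an amine, a carboxylic acid or a longer chain. They also leave open whether any such group would take the number in this assay beyond the scatter of compound 2.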